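Trading the dihydroxyphenyl ring of a chalcone for methoxyphenyl

The source may hold more compounds than are shown below. What is called first, only, known or untested is meant among the compounds shown, and "the series" means these compounds.

Measured compounds:
compound 1 `COc1cc(OC)c(OC)cc1/C=C/C(=O)c1ccc(O)cc1O` — 33800 nM
compound 2 `COc1cc(C(=O)/C=C/c2cc(OC)c(OC)cc2OC)ccc1O` — 95500 nM
compound 3 `COc1cc(OC)c(OC)cc1/C=C/C(=O)c1cccc(C(F)(F)F)c1` — a limit, > 150000 nM

All three were tested in a functional assay on MCF7 cells (Homo sapiens) for inhibition, read by MTT assay, with a stated time of 72 h; a higher number here means a weaker inhibitor, a lower number a stronger inhibitor. Compound 1 gives 33800 nM, the lowest of the two numbers reported. Compound 2 gives 95500 nM, a higher number that lies beyond the usual scatter. For compound 3 only a limit is known: it sits at the limit of > 150000 nM in this assay, at which 1 of the 3 values shown sits.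

Compound 4 `COc1ccc(C(=O)/C=C/c2cc(OC)c(OC)cc2OC)cc1` has not yet been measured. Against compound 1 the change is 4-methoxyphenyl in place of 2,4-dihydroxyphenyl on a carbonyl carbon. Among the measured compounds shown here, no step between two measured compounds isolates this change, so the expectation rests on the wider picture: compound 1, which keeps both hydroxy groups, gives 33800 nM, and compound 2 gives 95500 nM. For compound 3 only a limit is known. On that basis the step from compound 1 to compound 4 is expected to weaken inhibition, by a 2.5-fold higher number from compound 1 to compound 4 (0.40 log units; beyond the scatter), beyond the scatter. Compound 4 is accordingly estimated at 85000 nM, with a range from 35000 nM to 150000 nM in this assay.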

Compound 4, half-maximal inhibitory concentration: 33900 nM
The estimate for compound 4 lay 2.5-fold (0.40 log units) above the measured number; measured number below the stated range.
By their numbers in this assay, from the lowest: compounds 1 and 4 (each within the scatter of the next); then compound 2. At a limit, above all of these: compound 3.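

In this assay the change reads as a 1.0-fold higher number from compound 1 to compound 4 (0.00 log units; within the scatter) and so shows no difference in inhibition between 2,4-dihydroxyphenyl and 4-methoxyphenyl on this carbonyl carbon. Among the compounds shown here, the change removes both hydrogen-bond donors of the leaving group and brings in a group with none, so in this pair the number does not depend on those donors, which no step between the earlier compounds could show. For the compounds shown here, nothing measured here bears on why the two groups read alike, and this single pair is the only direct evidence for the change.

On these data alone, it remains open whether the same holds when only one of the two hydroxy groups is kept, or when the ring on the carbonyl carbon carries an amine or a carboxylic acid in place of the methoxy group. Also unresolved is whether a longer chain on that oxygen, such as an ethoxy or propoxy group, would leave the number in this assay where compound 4 stands, or whether the match with compound 1 is particular to these two groups.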